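From isobutyl to cyclohexyl on an aromatic nitrogen

The source may hold more compounds than are shown below. What is called first, only, known or untested is meant among the compounds shown, and "the series" means these compounds.

Measured in an ADME assay on C8166 cells (Homo sapiens) for cytotoxicity, read by MTT assay; on this read-out higher numbers stand for lower toxicity in this test and lower numbers for higher toxicity in this test:
- compound 1 `CCCCCn1cc(C(=O)O)c(=O)c2c(O)c(Cc3cccc(Cl)c3F)ccc21`: 39900 nM
- compound 2 `CC(C)Cn1cc(C(=O)O)c(=O)c2c(O)c(Cc3cccc(Cl)c3F)ccc21`: 19500 nM
- compound 3 `O=C(O)c1cn(C2CC2)c2ccc(Cc3cccc(Cl)c3F)c(O)c2c1=O`: 39100 nM

Among these three, compound 2, at 19500 nM, stands at the low end. The two steps that touch it are a 2.0-fold lower number from compound 1 to compound 2 (0.31 log units; beyond the scatter) and a 2.0-fold higher number from compound 2 to compound 3 (0.30 log units; within the scatter). Compound 4 `O=C(O)c1cn(C2CCCCC2)c2ccc(Cc3cccc(Cl)c3F)c(O)c2c1=O` has cyclohexyl in place of isobutyl on an aromatic nitrogen. Going by the values given here, no cyclohexyl compound has been measured, so the nearest evidence comes from the other changes at this nitrogen. These are a 2.0-fold higher number from compound 2 to compound 3 (0.30 log units; within the scatter) and a 1.0-fold lower number from compound 1 to compound 3 (0.01 log units; within the scatter), and neither is beyond the scatter. Among the compounds with values here, the only step that passes it, a 2.0-fold lower number from compound 1 to compound 2 (0.31 log units; beyond the scatter), does so barely. In this assay, within the data shown here, no step clearly beyond the scatter is therefore expected, though a small rise would fit the low standing of compound 2. The estimate means an expected 1.3-fold higher number from compound 2 to compound 4 (0.11 log units; within the scatter). Compound 4 is expected at 25000 nM, with an estimated range of 12000 nM to 50000 nM.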

Compound 4, half-maximal cytotoxic concentration: 17400 nM
Compound 4: the middle estimate sits 1.4-fold (0.16 log units) above what was measured, within the range that was stated.
By their numbers in this assay, from the lowest: compounds 4, 2, 3 and 1 (each within the scatter of the next, the first and the last beyond it).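

In the cytotoxicity test (this assay), cyclohexyl on the aromatic nitrogen cannot be told apart from isobutyl (a 1.1-fold lower number from compound 2 to compound 4 (0.05 log units; within the scatter)). It does, however, separate modestly from both cyclopropyl (a 2.2-fold lower number from compound 3 to compound 4 (0.35 log units; beyond the scatter)) and pentyl (a 2.3-fold lower number from compound 1 to compound 4 (0.36 log units; beyond the scatter)), so the two rings at this position, in compound 3 and compound 4, do not read alike, and having a ring there does not by itself set the number. The data shown give no explanation for these modest differences.

On these data alone, it remains open whether a phenyl ring or a chain ending in an amine or a hydroxyl group on this nitrogen would stay within the same narrow span. As far as these compounds go, it is also open whether a larger ring such as cycloheptyl would follow cyclohexyl or cyclopropyl.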